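The source may hold more compounds than are shown below. What is called first, only, known or untested is meant among the compounds shown, and "the series" means these compounds.

Measured so far in a functional assay (muscle tissue) with Cavia porcellus as the target; on this read-out lower numbers stand for an effect already at smaller amounts and higher numbers for an effect only at larger amounts of compound:
compound 1, `COC(=O)C1=C(C)N=C(C)/C(=C(\O)OC)C1c1cccc(OC)c1`, gives 191 nM
compound 2, `COC(=O)C1=C(C)N=C(C)/C(=C(\O)OC)C1c1ccccc1C(F)(F)F`, gives 1.51 nM
compound 3, `CCOc1ccccc1C1C(C(=O)OC)=C(C)N=C(C)/C1=C(\O)OC`, gives 110 nM

Compound 1 has the highest number of the three in this assay. Compound 3 sits within the scatter of compound 1, so no order between those two can be read; compound 2 lies far lower, well beyond the scatter.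

Compound 4, `COC(=O)C1=C(C)N=C(C)/C(=C(\O)OC)C1c1ccccc1C#N`, has not been measured. Its change from compound 1 is 2-cyanophenyl in place of 3-methoxyphenyl on a saturated ring carbon. Among the measured compounds shown here, no measured pair covers this exact change: nothing measured sets a 3-methoxyphenyl against a 2-cyanophenyl, and a nitrile appears nowhere among the measured compounds. For the measured compounds named here, the one single-point step, a 73-fold higher number from compound 2 to compound 3 (1.86 log units; beyond the scatter), shows how wide the spread among substituted phenyl groups can be, and it gives compound 2 as the low end of what such a group can reach here. The expectation for compound 4 rests on that spread only: a lower number in this assay than compound 1 is expected, with a step of a 38-fold lower number from compound 1 to compound 4 (1.58 log units; beyond the scatter), placing it closer to compound 2 than to compound 1 or compound 3. Compound 4 is thus expected to give 5 nM, within a range of 1.5 nM to 25 nM.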

Compound 4, half-maximal effective concentration: 15.9 nM
The estimate for compound 4 lay 3.2-fold (0.50 log units) below the measured number, and the stated range covers the measured number.
By their numbers in this assay, from the lowest: compound 2; then compound 4; then compounds 3 and 1 (each within the scatter of the next).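

In this assay, the nitrile gives a third distinct level at this aromatic carbon, with a 6.9-fold lower number from compound 3 to compound 4 (0.84 log units; beyond the scatter) when cyano replaces ethoxy and an 11-fold higher number from compound 2 to compound 4 (1.02 log units; beyond the scatter) when cyano replaces trifluoromethyl. With a 12-fold lower number from compound 1 to compound 4 (1.08 log units; beyond the scatter) for 2-cyanophenyl in place of 3-methoxyphenyl, a number far lower than those of compound 1 and compound 3 is no longer seen with trifluoromethyl alone, although compound 2 remains lower than compound 4 beyond the scatter. Nothing on hand accounts for this order of the groups.

The change from 3-methoxyphenyl to 2-cyanophenyl alters the group and its numbered location at once, and the compounds shown do not separate these two contributions. From the compounds shown here alone, it also remains open whether a chlorine atom, a methyl group or a carboxylic acid on the same aromatic carbon would read nearer compound 2, compound 4 or compound 3.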